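The compounds below may be only part of what the source reports. "The series", "measured", "known", "first", "only" and "open" are said of these compounds alone.

Compound 1 `CCOC(=O)c1cscc1-c1ccc(OC)c(OC)c1`: 3%
Compound 2 `CCOC(=O)c1c(-c2ccc(OC)c(OC)c2)csc1NC(N)=O`: 14%
Compound 3 `COCCOC(=O)c1c(-c2ccc(OC)c(OC)c2)csc1N`: 57%

Of the compounds shown here, three have been tested in an assay on isolated protein for inhibition of protein kinase C zeta type (Homo sapiens), with stated times of 1 h and 2.5 min, tested at 30 uM; a higher number here means more inhibition at the concentration tested (going by the name of the read-out), a lower number less inhibition. Compound 3 gives the highest of the three numbers: compound 2 lies lower, and compound 1 lower still, both gaps beyond the scatter. Compound 4 `COc1ccc(-c2csc(N)c2C(=O)OCc2ccc(C)cc2)cc1OC` differs from compound 3 by 4-methylphenyl in place of methoxymethyl on a saturated chain carbon bound to an oxygen next to a carbonyl group. Among the compounds with values here, the only measured step, a number 11 percentage points higher from compound 1 to compound 2 (beyond the scatter), concerns a different place on the shared core and so does not speak to this change. Within the data shown here, no measured step bears on the move from compound 3 to compound 4, and the direction of that move cannot be read from the data. The step of a number 7 percentage points lower from compound 3 to compound 4 (within the scatter) is expected to stay within the scatter. The estimate for compound 4 is 50%, with a range from 15% to 85%.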

Compound 4, a percentage reported as inhibition, at one concentration (the size of the read-out at that concentration, not a potency): 50%
Compound 4: middle estimate and measured number agree at the digits printed, and the stated range covers the measured number.
By their numbers in this assay, from the lowest: compound 1; then compound 2; then compounds 4 and 3 (each within the scatter of the next).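

At the saturated chain carbon bound to an oxygen next to a carbonyl group, replacing methoxymethyl with 4-methylphenyl gives a number 7 percentage points lower from compound 3 to compound 4 (within the scatter) in this assay. This pair therefore cannot be told apart, even though an aromatic ring enters and the hydrogen-bond acceptor of methoxymethyl leaves. No other measurement here bears on why the change makes so little difference.

On these data alone, whether the methyl group of 4-methylphenyl matters remains open, and a plain phenyl would test this. So does the effect of an amine or a carboxylic acid at this place.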